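This account rests on a few compounds, and the source may have more. Where it says the series, first, only, none or still open, it means among the compounds named here.

Measured compounds in the series so far:

compound 1 `OCc1cc2cc(/C(=N\O)Nc3cccc(F)c3)ccc2o1` — 2400 nM
compound 2 `OCc1cc2cc(/C(=N\O)Nc3cccc(Cl)c3)ccc2o1` — 5900 nM

In an assay on tissue (HeLa cells) for inhibition of Indoleamine 2,3-dioxygenase 1 (Homo sapiens), read by spectrophotometry (a higher number here means a weaker inhibitor, a lower number a stronger inhibitor), compound 2 holds the higher of the two numbers recorded. For the measured compounds named here, the only measured step, a 2.5-fold higher number from compound 1 to compound 2 (0.39 log units; beyond the scatter), concerns the halogen on the aromatic ring and nothing else.

Compound 3 `O/N=C(/Nc1cccc(Cl)c1)c1ccc2oc(COCC3CC3)cc2c1` keeps the chloro of compound 2 and differs from it in one place: cyclopropylmethyl in place of hydrogen on an oxygen on a saturated carbon. Going by the values given here, no measured pair changes anything at the hydroxymethyl group; the one step known, a 2.5-fold higher number from compound 1 to compound 2 (0.39 log units; beyond the scatter), does not touch that part of the molecule, so it gives no guide to the direction or size of the effect here. With nothing to set against it, the working assumption is that compound 3 stays near compound 2, with an unusually wide margin of uncertainty in either direction.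

The step of no change at the digits printed from compound 2 to compound 3 (within the scatter) is therefore expected to stay within the scatter. Compound 3 is estimated at 5900 nM, in the range 1500 nM to 20000 nM.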

Compound 3, half-maximal inhibitory concentration: 17600 nM
The estimate for compound 3 lay 3.0-fold (0.47 log units) below the measured number; the measured number falls inside the stated range.
By their numbers in this assay, from the lowest: compound 1; then compound 2; then compound 3.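

In this assay, for the compounds shown here, the step of a 3.0-fold higher number from compound 2 to compound 3 (0.47 log units; beyond the scatter) is the first reading at the hydroxymethyl group, and it goes towards weaker inhibition when cyclopropylmethyl replaces hydrogen on the oxygen. This position therefore responds to substitution, and a modest step is now on record at a part of the molecule away from the halogen. The free hydroxy is also not an absolute requirement for a numerical reading, as compound 3 still gives 17600 nM in this assay, and nothing measured on these compounds gives a reason for the step.

From the compounds shown here alone, whether the higher number goes with capping the oxygen in general or with cyclopropylmethyl in particular stays open, and a methyl ether, a longer chain or an amine in place of the hydroxy would help separate the two readings. Going by these compounds alone, the change at the oxygen is also seen only with chloro on the aromatic ring, so its size with the fluoro of compound 1 remains an open question.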